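Toxicity of a 3-chlorobenzyl analogue on the shared core

The compounds below may be only part of what the source reports. "The series", "measured", "known", "first", "only" and "open" are said of these compounds alone.

Compound 1 `CCC1(Cc2ccccc2)OS(=O)(=O)C=C1OCc1ccc(Cl)c(Cl)c1`: >= 20000 nM
Compound 2 `CCC1(Cc2ccccc2)OS(=O)(=O)C=C1OCc1ccc(C)cc1`: >= 16000 nM
Compound 3 `CCC1(Cc2ccccc2)OS(=O)(=O)C=C1OC`: > 400000 nM

In an ADME assay on HEL cells (Homo sapiens) for cytotoxicity, with a stated time of 3 days (a higher number here means that more compound is tolerated, a lower number that less compound is tolerated), compound 3 is not given as a number but as a limit, (the limit of > 400000 nM in this assay, at which 1 of the 3 values shown sits). Compound 1 also sits at a limit, (the limit of >= 20000 nM in this assay, at which 1 of the 3 values shown sits). Compound 2 likewise sits at a limit, (the limit of >= 16000 nM in this assay, at which 1 of the 3 values shown sits). All three readings are limits. Within the data shown here, no step between them can be sized: a step that the two limits leave unreadable from compound 1 to compound 3 and a step that the two limits leave unreadable from compound 2 to compound 3 both stay unreadable, as does a step that the two limits leave unreadable from compound 1 to compound 2.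

Compound 4 `CCC1(Cc2ccccc2)OS(=O)(=O)C=C1OCc1cccc(Cl)c1` has not been measured in this assay. It differs from compound 3 by 3-chlorophenyl in place of hydrogen on a saturated chain carbon bound to an oxygen on an unsaturated carbon. The closest measured steps are the ones in which compound 3 gains a 3,4-dichlorophenyl or a 4-methylphenyl at the same place, and both leave their size unreadable. Among the measured compounds shown here, the only guidance is that compound 1 and compound 2, which carry such an aryl group, were reported at limits far lower than the one seen for compound 3, so a drop of at least that kind is expected, an at least 20-fold lower number from compound 3 to compound 4 (1.30 log units; beyond the scatter). Compound 4 is therefore expected to be tolerated to about 20000 nM, in the range 8000 nM to 100000 nM, most likely again reported as a limit.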

Compound 4, minimum cytotoxic concentration: >= 20000 nM
Compound 4: no number, only a limit; the forecaster's own chance of this, stated with the estimate: 80%; the middle value lies on the limit itself.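

Compound 4 is reported only as a limit, so its steps to compound 1, compound 2 and compound 3 cannot be read: the limit of >= 20000 nM in this assay, at which 2 of the 4 values shown sit.

The compounds shown leave open the actual tolerated concentration of each compound in this assay, and whether compound 1, compound 2 and compound 4 truly differ.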